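The source may report more compounds than this note shows. Statements on the series, on what has been measured and on what is new or still open speak of the compounds shown alone.

Of the compounds shown here, three built on one shared core have been tested in a functional assay on HL-60 cells (Homo sapiens) for cytotoxicity, read by MTT assay, with a stated time of 4 days; a higher number here means a weaker inhibitor, a lower number a stronger inhibitor. Compound 1 `C=C1C[C@]23C[C@@]1(O)CC[C@H]2c1ccc(O)c(C)c1[C@@H]3Cn1cc(-c2ccc(C(F)(F)F)cc2)nn1` carries a trifluoromethyl on its phenyl ring and in this assay gives 8950 nM. Compound 3 `C=C1C[C@]23C[C@@]1(O)CC[C@H]2c1ccc(O)c(C)c1[C@@H]3Cn1cc(-c2ccc(OC)cc2)nn1`, with a methoxy in place of that trifluoromethyl, gives only a limit of the assay, > 20000 nM. Compound 2 `C=C1C[C@]23C[C@@]1(O)CC[C@H]2c1cc(Br)c(O)c(C)c1[C@@H]3Cn1cc(-c2ccc(OC)cc2)nn1`, which adds a bromo to the shared core, likewise gives only a limit, > 20000 nM. Compound 2 thus stands at the limit of > 20000 nM in this assay, at which 2 of the 3 values shown sit, together with compound 3, with no number of its own.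

Compound 4 `C=C1C[C@]23C[C@@]1(O)CC[C@H]2c1cc(Br)c(O)c(C)c1[C@@H]3Cn1cc(-c2ccc(C)cc2)nn1` differs from compound 2 in one place: methyl in place of methoxy on an aromatic carbon. For the measured compounds named here, two measured steps touch on this change. The step of an at least 2.2-fold higher number from compound 1 to compound 3 (0.34 log units; beyond the scatter) shows that the methoxy variant fell beyond the assay's reach. The step that the two limits leave unreadable from compound 2 to compound 3 leaves the effect of bromo unreadable. Going by the values given here, no measured pair shows whether methyl behaves more like methoxy or more like trifluoromethyl. For compound 4 the expected step is therefore a number no higher from compound 2 to compound 4 (the limit leaves the size open). For compound 4 the estimate is a value of about 20000 nM, between 7000 nM and 50000 nM.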

Compound 4, half-maximal inhibitory concentration: > 20000 nM
Compound 4: no number, only a limit (the forecaster's own chance of this, stated with the estimate: 55%); the middle value lies on the limit itself.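

For the compounds shown here, compound 2 and compound 4 both give only a limit in this assay, not a number, and no step between them can be read. The compounds shown leave open how far past that limit each lies, and whether methyl in place of methoxy changes their strength at all.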